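The source may hold more compounds than are shown below. What is called first, only, known or untested is meant among the compounds shown, and "the series" means these compounds.

Compound 2, `CCS(=O)(=O)Nc1cc(-c2ccc3ncnc(Nc4ccc(F)cc4)c3c2)cnc1OC`, gives 3160 nM in a functional assay on HCT-116 cells (Homo sapiens) for cytotoxicity, read by sulforhodamine B assay, with a stated time of 72 h; a lower number here means a stronger inhibitor, a higher number a weaker inhibitor. That is the lowest of the three numbers recorded, but only by margins inside the scatter: compound 1, `CCS(=O)(=O)Nc1cc(-c2ccc3ncnc(Nc4cccc(F)c4)c3c2)cnc1OC`, gives 3940 nM, and compound 3, `CCS(=O)(=O)Nc1cc(-c2ccc3ncnc(Nc4ccc(F)cc4F)c3c2)cnc1OC`, gives 4010 nM. The measured steps are a 1.2-fold lower number from compound 1 to compound 2 (0.10 log units; within the scatter), a 1.0-fold higher number from compound 1 to compound 3 (0.01 log units; within the scatter) and a 1.3-fold higher number from compound 2 to compound 3 (0.10 log units; within the scatter); each moves a fluorine around the same aromatic ring and none rises above the scatter. Compound 4, `CCS(=O)(=O)Nc1cc(-c2ccc3ncnc(Nc4ccc(OC)cc4)c3c2)cnc1OC`, differs from compound 2 by methoxy in place of fluoro on an aromatic carbon. Going by the values given here, no measured step exchanges fluoro for methoxy, so the bearing of the three steps is indirect; since all of them were flat, the step in this assay is expected to be small as well, a 1.1-fold higher number from compound 2 to compound 4 (0.04 log units; within the scatter). Compound 4 is therefore estimated at 3500 nM, ranging from 1500 nM to 8000 nM.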

Compound 4, half-maximal inhibitory concentration: 3490 nM
Compound 4: the middle estimate sits 1.0-fold (0.00 log units) above what was measured, and the stated range covers the measured number.
By their numbers in this assay, from the lowest: compounds 2, 4, 1 and 3 (each within the scatter of the next).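

Replacing fluoro with methoxy on this aromatic carbon adds a heavy atom and a hydrogen-bond acceptor, yet in this assay the step stays within the scatter (a 1.1-fold higher number from compound 2 to compound 4 (0.04 log units; within the scatter)). The steps from the other two fluorinated rings are equally small (a 1.1-fold lower number from compound 3 to compound 4 (0.06 log units; within the scatter); a 1.1-fold lower number from compound 1 to compound 4 (0.05 log units; within the scatter)), so among these four compounds, a first group other than fluoro at this position leaves the number within the scatter. Nothing available offers an explanation for this.

Still open, going by these compounds, is whether an amine, a carboxylic acid or a longer chain at this position would give a step beyond the scatter.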